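Swapping the Amide Ring on an Inactive Series

A few compounds are considered here, and "the series" means these few. Any claim that something is new, unique, unknown or untested is made for them only; others in the source may bear on it.

Of the compounds shown here, three sharing one core have been measured in an assay on HEK293 cells for negative allosteric modulation of metabotropic glutamate receptor 5 (Homo sapiens), read by FLIPR; on this read-out higher numbers stand for weaker inhibition and lower numbers for stronger inhibition. Compound 1 `CC1CCCC(C(=O)N2CC(c3nc(-c4cccc(Cl)c4)no3)C2)C1` carries a 3-methylcyclohexyl group on the carbonyl carbon. In this assay compound 1 gives only a limit, > 10000 nM. Compound 2 `O=C(N1CCCCC1)N1CC(c2nc(-c3cccc(Cl)c3)no2)C1` has a piperidin-1-yl group in that place. In this assay compound 2 likewise reaches only a limit, > 10000 nM. Compound 3 `O=C(C1CCC(F)(F)CC1)N1CC(c2nc(-c3cccc(Cl)c3)no2)C1` bears a 4,4-difluorocyclohexyl group on the carbonyl carbon. In this assay compound 3 also gives only a limit, > 10000 nM. Because all three values sit at the limit of > 10000 nM in this assay, at which 3 of the 3 values shown sit, none of the steps between them can be read: a step that the two limits leave unreadable from compound 1 to compound 2, a step that the two limits leave unreadable from compound 1 to compound 3 and a step that the two limits leave unreadable from compound 2 to compound 3 have no size or direction. Compound 3 therefore stands level with the other two at the limit.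

Compound 4 `CC1CN(C(=O)N2CC(c3nc(-c4cccc(Cl)c4)no3)C2)CC(C)O1` differs from compound 3 in one place: 2,6-dimethylmorpholin-4-yl in place of 4,4-difluorocyclohexyl on a carbonyl carbon. The three measured steps give no readable size, so they offer no guide to this change beyond showing that three different rings on the carbonyl carbon all left the compounds at the limit. The expectation is that compound 4 behaves the same way, so the step that the limit leaves unreadable from compound 3 to compound 4 is estimated to be none beyond the scatter. Compound 4 is thus expected to give about 15000 nM, between 5000 nM and 50000 nM, most likely again as a limit.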

Compound 4, half-maximal inhibitory concentration: 990 nM
Compound 4: middle estimate off by 15-fold (1.18 log units), on the high side, outside the stated range (below it).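

The ring on the carbonyl carbon is not a place where every change leaves the compounds at the limit, as the first three compounds alone might have suggested. In this assay, 2,6-dimethylmorpholin-4-yl gives an at least 10-fold lower number from compound 3 to compound 4 (1.00 log units; beyond the scatter), and the same group gives an at least 10-fold lower number from compound 2 to compound 4 (1.00 log units; beyond the scatter) and an at least 10-fold lower number from compound 1 to compound 4 (1.00 log units; beyond the scatter), so it stands apart from all three earlier rings, even though it has the same heavy-atom count as the 4,4-difluorocyclohexyl group it replaces. Each of these steps is only a minimum size, because the true value of each partner compound lies somewhere beyond the measured range: the limit of > 10000 nM in this assay, at which 3 of the 4 values shown sit.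

The compounds shown leave open whether the ring oxygen, the methyl groups or both account for the step, since compound 4 differs from compound 2 in both features at once. A plain morpholin-4-yl group would help separate these two features, while a piperazin-1-yl group, with an amine nitrogen in that ring, would test whether another hetero atom in the ring can serve in the same way.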